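A few compounds are considered here, and "the series" means these few. Any claim that something is new, unique, unknown or untested is made for them only; others in the source may bear on it.

Notes on the series. In an in vitro functional assay on HEK285-7 cells for antagonist activity at prostaglandin D2 receptor 2 (Homo sapiens), read by BRET and beta-arrestin recruitment (a higher number here means a weaker inhibitor, a lower number a stronger inhibitor), compound 1 `O=C(O)Cc1sc(C(c2ccccc2)c2ccccc2)nc1-c1ccccc1` gives 370 nM. Compound 3 `O=C(O)Cc1sc(C(c2ccc(F)cc2)c2ccc(F)cc2)nc1-c1ccoc1` gives 130 nM, so compound 1 stands highest of the two numbers, with compound 3 its nearest neighbour. Compound 2 `O=C(O)Cc1sc(C(c2ccc(F)cc2)c2ccc(F)cc2)nc1-c1ccnc(N2CCCC2)c1` returns only a limit, > 100000 nM, and sits at the limit of > 100000 nM in this assay, at which 1 of the 3 values shown sits. Among the measured compounds shown here, the single measured step, an at least 760-fold lower number from compound 2 to compound 3 (2.88 log units; beyond the scatter), alters the group on an aromatic carbon of the shared core, the same place that compound 4 `COc1ccc(OC)c(-c2nc(C(c3ccccc3)c3ccccc3)sc2CC(=O)O)c1` alters through (2,5-dimethoxyphenyl in place of phenyl on an aromatic carbon). Here one six-membered aromatic ring of carbon only replaces another, a far gentler change than the measured step, so a step of modest size is expected, direction uncertain. Compound 4 is expected to give 250 nM, within 60 nM to 1500 nM, meaning an expected 1.5-fold lower number from compound 1 to compound 4 (0.17 log units; within the scatter).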

Compound 4, half-maximal inhibitory concentration: > 100000 nM
Compound 4: no number, only a limit; the forecaster's own chance of this, stated with the estimate: 5%; at least 400-fold (2.60 log units) between middle value and limit.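

Among the compounds shown here, the position on the aromatic carbon next to the ring nitrogen proves far less tolerant than the earlier compounds showed: keeping a six-membered aromatic ring of carbon only does not preserve activity in this assay, as 2,5-dimethoxyphenyl in place of phenyl gives an at least 270-fold higher number from compound 1 to compound 4 (2.43 log units; beyond the scatter). The entry for compound 4 is a limit, not a number. Such a loss at this position therefore no longer belongs to the 2-(pyrrolidin-1-yl)pyridin-4-yl group alone: the limit of > 100000 nM in this assay, at which 2 of the 4 values shown sit.

Which methoxy group accounts for the step stays open. Phenyl carrying a single methoxy group, or a methyl group in its place, would bear on this.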